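The source may hold more compounds than are shown below. What is called first, only, known or untested is meant among the compounds shown, and "the series" means these compounds.

Measured in an ADME assay on HEK-293T cells (Homo sapiens) for inhibition, read by luminescence, with a stated time of 72 h, tested at 5 uM; on this read-out lower numbers stand for less inhibition of growth and higher numbers for more inhibition of growth at the one concentration tested:
compound 1 `C=CS(=O)(=O)NC/C=C/c1cc(OC)cc(O)c1C(=O)OC(C)C`: 0.1%
compound 2 `C=CS(=O)(=O)NC/C=C/c1cc(OC)cc(O)c1C(=O)OCC(C)c1ccccc1`: 22.5%
compound 3 `COc1cc(O)c(C(=O)OCC(C)c2ccccc2)c(/C=C/CN2C(=O)C=CC2=O)c1`: 0%

Compound 3 stands level with compound 1 within the scatter and under compound 2, as a number 22.5 percentage points lower from compound 2 to compound 3 (beyond the scatter) shows. Compound 4 `COc1cc(O)c(C(=O)OC(C)C)c(/C=C/CN2C(=O)C=CC2=O)c1` keeps the rest of compound 3 and differs in one place: isopropyl in place of 2-phenylpropyl on an oxygen next to a carbonyl group. Only the opposite swap has been measured, a number 22.4 percentage points higher from compound 1 to compound 2 (beyond the scatter), and it carried a different group on the saturated chain carbon. Reversed, that step would point downward, yet compound 3 already gives 0%. No step beyond the scatter is therefore expected in this assay. The expected change is a number 3 percentage points higher from compound 3 to compound 4 (within the scatter). For compound 4 the estimated value is 3%, with an expected range from 0% to 15%.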

Compound 4, percent growth inhibition at one concentration: 8%
The estimate for compound 4 lay 5 percentage points below the measured number, within the range that was stated.
By their numbers in this assay, from the lowest: compounds 3, 1 and 4 (each within the scatter of the next); then compound 2.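

In this assay, isopropyl in place of 2-phenylpropyl on an oxygen next to a carbonyl group gives a number 8 percentage points higher from compound 3 to compound 4 (within the scatter), so this position shows no step beyond the scatter when the ring-bearing group sits on the saturated chain carbon. With isopropyl kept, changing the ring-free group to the ring-bearing one likewise gives a number 7.9 percentage points higher from compound 1 to compound 4 (within the scatter). The earlier gain from 2-phenylpropyl therefore does not carry over between the two cores: the same change on two cores in this assay, a number 22.4 percentage points higher (beyond the scatter) from compound 1 to compound 2 and a number 8 percentage points lower (within the scatter) from compound 4 to compound 3, 30.4 percentage points apart, beyond the scatter of two such steps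

From the compounds shown here alone, whether a benzyl group on that oxygen would raise growth inhibition on the ring-bearing core remains open. So does the outcome of placing an amine on the saturated chain carbon.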